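Quinolin-8-yl gives way to quinolin-6-yl

The source may hold more compounds than are shown below. What is called first, only, known or untested is meant among the compounds shown, and "the series" means these compounds.

Measured in a functional assay on K562 cells (Homo sapiens) for inhibition, read by trypan blue exclusion, with a stated time of 72 h; on this read-out higher numbers stand for weaker inhibition and lower numbers for stronger inhibition:
- compound 1 `Cn1c(=O)c(S(=O)(=O)c2ccccc2)cc2cnc(Nc3ccc4ncccc4c3)nc21`: 100000 nM
- compound 2 `Cc1ccc(S(=O)(=O)c2cc3cnc(Nc4cccc5cccnc45)nc3n(C)c2=O)cc1`: 10000 nM

Of these two, compound 2 has the lower number in this assay, and the gap to compound 1 lies beyond the scatter. Compound 3 `Cc1ccc(S(=O)(=O)c2cc3cnc(Nc4ccc5ncccc5c4)nc3n(C)c2=O)cc1` has quinolin-6-yl in place of quinolin-8-yl on a nitrogen on an aromatic ring. Compound 1, which also carries quinolin-6-yl, gives 100000 nM, so a moderate move towards a higher number, meaning weaker inhibition, is expected. The estimated change is a 3.0-fold higher number from compound 2 to compound 3 (0.48 log units; beyond the scatter). For compound 3 the expected value is 30000 nM, with an estimated range from 6000 nM to 100000 nM.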

Compound 3, half-maximal inhibitory concentration: 10000 nM
For compound 3 the middle estimate is 3.0-fold (0.48 log units) above the measured one; the measured number falls inside the stated range.
By their numbers in this assay, from the lowest: compounds 2 and 3 (each within the scatter of the next); then compound 1.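

In this assay, quinolin-6-yl in place of quinolin-8-yl on the nitrogen gives no change at the digits printed from compound 2 to compound 3 (within the scatter), so with the methyl present, this rearrangement of the same atoms shows no measurable effect. Methyl in place of hydrogen on an aromatic carbon gives a 10-fold lower number from compound 1 to compound 3 (1.00 log units; beyond the scatter), making this the only one of the two single changes that lies beyond the scatter. No available data bear on the reason for either result.

As far as these compounds go, it remains open whether a methoxy group or a chlorine atom in place of that methyl would give a lower number. Whether an isoquinolinyl group on the nitrogen would behave like either quinolinyl group is also unresolved.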